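This account rests on a few compounds, and the source may have more. Where it says the series, first, only, none or still open, it means among the compounds named here.

Measured compounds:
- Compound 1, `CC1(C)OC(=O)C(=CNc2ccccc2-c2nc3ccccc3s2)C(=O)O1`: in an ADME assay on MT4 cells (Homo sapiens) for cytotoxicity, read by MTT assay, with a stated time of 4 days (a higher number here means that more compound is tolerated, a lower number that less compound is tolerated), compound 1 gives 41600 nM.
- Compound 2, `CC1(C)OC(=O)C(=CNc2cccc(-c3nc4ccccc4s3)c2)C(=O)O1`: in this assay compound 2 gives > 190000 nM, which is a limit of the assay rather than a number.
- Compound 3, `O=c1cc[nH]c2c(-c3nc4ccccc4s3)cccc12`: in this assay compound 3 gives 8600 nM.

Among the two actual numbers in this assay, compound 1 stands highest, so cells tolerate more of it than of compound 3, whose value lies lower by a gap beyond the usual scatter. The third value belongs to compound 2, and the limit of > 190000 nM in this assay, at which 1 of the 3 values shown sits, shows that it is a limit, not a number.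

The next compound, compound 4, `CC1(C)OC(=O)C(=CNc2ccccc2[N+](=O)[O-])C(=O)O1`, differs from compound 1 in a single spot: nitro in place of 1,3-benzothiazol-2-yl on an aromatic carbon. The rest of the core of compound 1 is kept.

For the measured compounds named here, no pair of measured compounds differs in only one place, so no measured step guides the size of this change. The step from compound 1 to compound 4 is expected to be a moderate rise in this assay, meaning more compound tolerated, estimated as a 2.4-fold higher number from compound 1 to compound 4 (0.38 log units; beyond the scatter). For compound 4 the estimated value in this assay is 100000 nM, within a range from 30000 nM to 190000 nM.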

Compound 4, half-maximal cytotoxic concentration: >= 411000 nM
Compound 4: only a limit was reported (the forecaster's own chance of this, stated with the estimate: 40%); middle value at least 4.1-fold (0.61 log units) from the limit.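

In this assay, for the compounds shown here, this is the first change in a single place that can be read, and it is large: nitro in place of 1,3-benzothiazol-2-yl on an aromatic carbon gives an at least 9.8-fold higher number from compound 1 to compound 4 (0.99 log units; beyond the scatter). So what sits at this place on the six-membered aromatic ring of carbon only, ortho to a large group, clearly matters for how much compound the cells tolerate, and here the group with no ring goes with far more compound tolerated than the two-ring group it replaces. The result for compound 4 is a limit of the assay and not a number: the limit of >= 411000 nM in this assay, at which 1 of the 4 values shown sits.

From the compounds shown here alone, how far the step truly reaches therefore stays open, and a single swap cannot tell whether the rise follows from losing the 1,3-benzothiazol-2-yl group or from gaining the nitro group. Going by these compounds, a small group such as an amine, a methoxy group or a carboxylic acid at the same place, or a plain hydrogen there, would help separate these two readings, and it also remains open whether the same swap would give a similar rise on another core.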